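Chloro to hydrogen on the pendant aryl ring

The source may hold more compounds than are shown below. What is called first, only, known or untested is meant among the compounds shown, and "the series" means these compounds.

Compound 1 `COc1cc(/C=C/C(=O)c2cccc(-n3cc(-c4ccc(Cl)cc4)[nH]c3=O)c2)cc(OC)c1OC` is reported in a functional assay on NCI-H226 cells (Homo sapiens) for inhibition (a higher number here means a weaker inhibitor of growth, a lower number a stronger inhibitor of growth), as "not active" (no number reported), so it stands without a number in this assay. Compound 2 `COc1cc(/C=C/C(=O)c2cccc(-n3cc(-c4ccccc4)[nH]c3=O)c2)ccc1O` carries the same unsubstituted phenyl group that compound 3 will carry but a different substitution pattern on the cinnamoyl ring; in this assay compound 2 gives 2600 nM. Between compound 1 and compound 2 no single-point comparison exists, and only these two readings are known. Compound 3 `COc1cc(/C=C/C(=O)c2cccc(-n3cc(-c4ccccc4)[nH]c3=O)c2)cc(OC)c1OC` is the next compound to be tested. Compound 3 differs from compound 1 by hydrogen in place of chloro on an aromatic carbon. Among the measured compounds shown here, no measured step covers this change in this assay. Since compound 1 returned no number, any measurable reading for compound 3 would count as a move toward stronger growth inhibition, yet a reading beyond the assay limit is about as likely as not. Compound 3 is expected to give about 8000 nM in this assay, within 2000 nM to 40000 nM, a loose expectation because compound 2 gives 2600 nM.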

Compound 3, concentration for 50% growth inhibition: 14600 nM
Compound 3: middle estimate off by 1.8-fold (0.26 log units), on the low side; the measured number falls inside the stated range.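

In this assay compound 1 reads "not active" (no number reported) and compound 3 reads 14600 nM and no step can be read between them. The compounds shown leave open the size of the change from 4-chlorophenyl to phenyl. Nothing at hand bears on a cause of these readings.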